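Thiophen-3-yl in place of furan-3-yl on compound 2

A few compounds are considered here, and "the series" means these few. Any claim that something is new, unique, unknown or untested is made for them only; others in the source may bear on it.

Compound 1 `C#Cc1cn([C@@H]2O[C@H](CO)[C@@H](O)[C@H]2O)c2ncnc(SC)c12` gives 50 nM
Compound 2 `COc1nc(N)nc2c1c(-c1ccoc1)cn2[C@@H]1O[C@H](CO)[C@@H](O)[C@H]1O` gives > 20000 nM as a limit

In a functional assay on HL-60 cells (Homo sapiens) for antiproliferative activity, read by XTT assay, with a stated time of 72 h (on this read-out lower numbers stand for stronger inhibition and higher numbers for weaker inhibition), compound 1 gives 50 nM as a measured number. Compound 2 stands at the limit of > 20000 nM in this assay, at which 1 of the 2 values shown sits, and so has a limit, not a number. Compound 3 `COc1nc(N)nc2c1c(-c1ccsc1)cn2[C@@H]1O[C@H](CO)[C@@H](O)[C@H]1O` carries thiophen-3-yl in place of furan-3-yl on an aromatic carbon and otherwise matches compound 2. Within the data shown here, no measured pair shows this exchange, and no step beyond the usual scatter is expected in this assay in either direction. The estimate means a number no higher from compound 2 to compound 3 (the limit leaves the size open) as the expected step. Compound 3 is expected at 20000 nM within an estimated range of 6000 nM to 30000 nM in that read-out.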

Compound 3, half-maximal inhibitory concentration: > 20000 nM
Compound 3: a limit, no number (the forecaster's own chance of this, stated with the estimate: 70%); the middle value lies on the limit itself.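

No step can be read from compound 2 to compound 3, because both values are limits, not numbers: the limit of > 20000 nM in this assay, at which 2 of the 3 values shown sit. The compounds shown leave open whether thiophen-3-yl and furan-3-yl differ at all on this shared core.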